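Chlorobenzyl dithiocarbamates: a positional isomer with no readable anchor

The source may report more compounds than this note shows. Statements on the series, on what has been measured and on what is new or still open speak of the compounds shown alone.

Compound 1 `CC(C)(C)OC(=O)N1CCN(C(=S)SCc2cn(Cc3ccc(Cl)cc3)nn2)CC1` is the starting point of this note. In a functional assay on PC-3 cells (Homo sapiens) for inhibition, read by MTT assay, with a stated time of 72 h (on this read-out lower numbers stand for stronger inhibition and higher numbers for weaker inhibition), compound 1 gives > 128000 nM, which is a limit of the assay rather than a number. Compound 2 `S=C(SCc1cn(Cc2ccc(Cl)cc2)nn1)N1CCNCC1` gives > 128000 nM in this assay, again only a limit. Compound 3 `CC(C)(C)OC(=O)N1CCN(C(=S)SCc2cn(CCOc3ccc4ccc(=O)oc4c3)nn2)CC1` gives > 128000 nM in this assay, also a limit. Going by the values given here, the one step between measured compounds, hydrogen in place of tert-butoxycarbonyl on an amine nitrogen in a ring, reads a step that the two limits leave unreadable from compound 1 to compound 2; both of its ends sit at the limit of > 128000 nM in this assay, at which 3 of the 3 values shown sit, so its size cannot be taken from the numbers. Compound 4 `CC(C)(C)OC(=O)N1CCN(C(=S)SCc2cn(Cc3ccccc3Cl)nn2)CC1` differs from compound 1 by 2-chlorophenyl in place of 4-chlorophenyl on a saturated chain carbon bound to an aromatic nitrogen. Among the compounds with values here, no measured step touches this change, and the single step available is itself unreadable, so the series sets neither size nor direction for it. Compound 4 is therefore expected to remain at the limit, with an estimated step that the limit leaves unreadable from compound 1 to compound 4 that stands for no change readable beyond the scatter. The estimate for compound 4 is 200000 nM, with a range from 40000 nM to 1000000 nM.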

Compound 4, half-maximal inhibitory concentration: 12500 nM
The estimate for compound 4 lay 16-fold (1.20 log units) above the measured number; measured number below the stated range.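

In this assay, 2-chlorophenyl in place of 4-chlorophenyl on a saturated chain carbon bound to an aromatic nitrogen gives an at least 10-fold lower number from compound 1 to compound 4 (1.01 log units; beyond the scatter), so the series responds to where the chlorine stands on this ring, although the two compounds have the same atoms. Because compound 1 sits at a limit, this step fixes the direction but gives only a minimum for the size. The earlier step cannot be read, and compound 4 alone leaves the limit: the limit of > 128000 nM in this assay, at which 3 of the 4 values shown sit.

As far as these compounds go, whether the 2-chlorophenyl result holds with hydrogen in place of tert-butoxycarbonyl on the amine nitrogen in the ring remains open. Also open, from the compounds shown here alone, is how a 2-methoxyphenyl or an unsubstituted phenyl would read at this place.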